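From 2-aminophenyl to hydroxy on an amide-type nitrogen

The compounds below may be only part of what the source reports. "The series", "measured", "known", "first", "only" and "open" are said of these compounds alone.

Measured in a functional assay on CAL-27 cells (Homo sapiens) for cytotoxicity, read by resazurin assay; a higher number here means a weaker inhibitor, a lower number a stronger inhibitor:
Compound 1 `Nc1ccccc1NC(=O)c1ccc(COc2ccc3ncnc(Nc4cccc(Br)c4)c3c2)cc1`: 620 nM
Compound 2 `C#Cc1cccc(Nc2ncnc3ccc(S(=O)(=O)n4ccc(/C=C/C(=O)Nc5ccccc5N)c4)cc23)c1`: 2500 nM

Among the compounds with values here, only two values are available so far. Compound 2, at 2500 nM, has the higher number of the pair, which makes it the weaker inhibitor of the two, and its gap to compound 1 lies beyond the usual scatter of repeated measurements.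

The next compound, compound 3 `C#Cc1cccc(Nc2ncnc3ccc(S(=O)(=O)n4ccc(/C=C/C(=O)NO)c4)cc23)c1`, keeps all of compound 2 except at one end of the molecule: hydroxy in place of 2-aminophenyl on an amide-type nitrogen. The group that enters is much smaller than the one that leaves. Within the data shown here, no measured pair shows this change, so the expectation rests on the structural change alone and the range is kept wide. A move towards stronger inhibition is expected, with an estimated 6.3-fold lower number from compound 2 to compound 3 (0.80 log units; beyond the scatter). In this assay, compound 3 is estimated at 400 nM, with an expected range from 80 nM to 2000 nM.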

Compound 3, half-maximal inhibitory concentration: 160 nM
Beside the measured number, compound 3's estimate is 2.5-fold (0.40 log units) above it, within the range that was stated.
By their numbers in this assay, from the lowest: compound 3; then compound 1; then compound 2.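

Within the data shown here, this is the first comparison in which only one place changes, and it shows that the group on the amide-type nitrogen strongly affects the result in this assay: hydroxy in place of 2-aminophenyl gives a 16-fold lower number from compound 2 to compound 3 (1.19 log units; beyond the scatter). The 2-aminophenyl ring is therefore not required for activity in this compound, and a much smaller group gives a stronger inhibitor on this core. No measurement shown here explains the size of this step.

The step removes the aromatic ring and its amino group and adds hydroxy all at once, so the contribution of each change cannot be separated. From the compounds shown here alone, a plain phenyl, a methoxy or an unsubstituted amide on the same nitrogen could help separate them, and the effect of this change on the core of compound 1 remains open.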